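The source may report more compounds than this note shows. Statements on the series, on what has been measured and on what is new or still open speak of the compounds shown alone.

Compound 1 `Oc1ccc(-c2cc(-c3cccc(O)c3)nc(-c3cccc(O)c3)c2)cc1` gives 1760 nM in a functional assay on DU-145 cells (Homo sapiens) for cytotoxicity, read by CCK-8 assay, with a stated time of 4 days; a lower number here means a stronger inhibitor, a higher number a weaker inhibitor. Compound 3 `Oc1ccc(-c2cc(-c3cccc(O)c3)cc(-c3cccc(O)c3)n2)cc1` gives 1940 nM in this assay. Compound 2 `Oc1cccc(-c2cc(-c3cccc(O)c3)nc(-c3ccccc3O)c2)c1` gives only a limit in this assay, > 50000 nM (the limit of > 50000 nM in this assay, at which 1 of the 3 values shown sits).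

Among the two numbers, compound 3 stands highest, with compound 1 nearest and within the scatter of it. Compound 4 `Oc1cccc(-c2cc(-c3cccc(O)c3)nc(-c3cccc(O)c3)c2)c1` differs from compound 3 by 3-hydroxyphenyl in place of 4-hydroxyphenyl on an aromatic carbon. Among the measured compounds shown here, the one step measured at this carbon, an at least 25-fold lower number from compound 2 to compound 3 (1.41 log units; beyond the scatter), was large, but it swapped a 2-hydroxyphenyl for a 4-hydroxyphenyl; no measured step swaps a 4-hydroxyphenyl for a 3-hydroxyphenyl. Compound 1 and compound 3, which differ in the same two groups at another carbon, sit within the scatter of each other. Compound 4 is therefore expected near compound 3, with a 1.2-fold lower number from compound 3 to compound 4 (0.08 log units; within the scatter) within the scatter. The estimate for compound 4 is 1600 nM, from 500 nM to 5000 nM.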

Compound 4, half-maximal inhibitory concentration: 4040 nM
Compound 4: middle estimate off by 2.5-fold (0.40 log units), on the low side; the measured number falls inside the stated range.
By their numbers in this assay, from the lowest: compounds 1 and 3 (each within the scatter of the next); then compound 4. At a limit, above all of these: compound 2.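

Next to the ring nitrogen, the 3-hydroxyphenyl and 4-hydroxyphenyl groups are not interchangeable, with a 2.1-fold higher number from compound 3 to compound 4 (0.32 log units; beyond the scatter), and the same swap at another carbon of the shared core goes the same way, with a 2.3-fold higher number from compound 1 to compound 4 (0.36 log units; beyond the scatter). The 3-hydroxyphenyl group still lies far from the 2-hydroxyphenyl group at this position, with an at least 12-fold lower number from compound 2 to compound 4 (1.09 log units; beyond the scatter). Compound 2 gives no number here, only a limit: the limit of > 50000 nM in this assay, at which 1 of the 4 values shown sits.

On these data alone, what a methoxy group, an amine or a carboxylic acid would do in place of the hydroxyl at this position stays open.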